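Adding an Ether Side Chain to Compound 1

This account rests on a few compounds, and the source may have more. Where it says the series, first, only, none or still open, it means among the compounds named here.

Compound 1 `N#Cc1ncc2nc1OCC/C=C\COc1ccccc1NC(=O)N2` was examined in a functional assay on NCI-H1299 cells (Homo sapiens), read by flow cytometry; on this read-out lower numbers stand for an effect already at smaller amounts and higher numbers for an effect only at larger amounts of compound. In this assay compound 1 reaches only the limit of the assay, > 10000 nM, and gives no number. Compound 2 `CCOc1ccc2c(c1)NC(=O)Nc1cnc(C#N)c(n1)OCCCCCO2` belongs to the same series. In this assay compound 2 likewise gives only the limit, > 10000 nM. Both values shown therefore sit at the limit of > 10000 nM in this assay, at which 2 of the 2 values shown sit, so compound 1 cannot be placed above or below its companion; the two values say no more than that neither compound acts within the tested range.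

Compound 3 `N#Cc1ncc2nc1OCC/C=C\COc1ccc(OCCOC3CCCCO3)cc1NC(=O)N2` has not yet been measured in this assay. It differs from compound 1 by 2-((oxan-2-yl)oxy)ethoxy in place of hydrogen on an aromatic carbon. Among the measured compounds shown here, no step between two measured compounds has been recorded, so nothing measured shows what this change does. With both known values at the limit, a step toward lower numbers large enough to yield a measured value is not expected; the step is estimated as a step that the limit leaves unreadable from compound 1 to compound 3, that is, none beyond the scatter. For compound 3 the expected value in this assay is 15000 nM, within a range of 3000 nM to 60000 nM.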

Compound 3, half-maximal effective concentration: > 10000 nM
Compound 3 gave a limit, no number (the forecaster's own chance of this, stated with the estimate: 75%); the middle value lies beyond the limit too.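

In this assay compound 3 gives > 10000 nM, a limit of the assay and not a number. No step from compound 1 to compound 3 can be read, since all the values stand at one limit: the limit of > 10000 nM in this assay, at which 3 of the 3 values shown sit.

The compounds shown leave open whether 2-((oxan-2-yl)oxy)ethoxy changes the effect at all, and whether any compound of this series acts within the tested range.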